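This account rests on a few compounds, and the source may have more. Where it says the series, first, only, none or still open, it means among the compounds named here.

For the measured compounds named here, compound 2 `COc1cc2ncnc(Nc3ccc(OC(F)(F)F)cc3)c2cc1OCCCCC(=O)Nc1ccc(S(N)(=O)=O)cc1` has the highest number of the two values so far in a functional assay on NCI-H1975 cells (Homo sapiens) for antiproliferative activity, read by MTT assay, with a stated time of 72 h; on this read-out higher numbers stand for weaker inhibition and lower numbers for stronger inhibition; the nearest is compound 1 `COc1cc2ncnc(Nc3ccc(Cl)c(C(F)(F)F)c3)c2cc1OCCCCC(=O)Nc1ccc(S(N)(=O)=O)cc1`, which gives 3220 nM, while compound 2 gives 8770 nM. Compound 3 `COc1cc2ncnc(Nc3cccc(C)c3)c2cc1OCCCCC(=O)Nc1ccc(S(N)(=O)=O)cc1` differs from compound 2 by 3-methylphenyl in place of 4-(trifluoromethoxy)phenyl on a nitrogen on an aromatic ring. Going by the values given here, only one measured step, a 2.7-fold higher number from compound 1 to compound 2 (0.44 log units; beyond the scatter), bears on this position, and it shows that exchanging the group here can shift the number by a modest amount. Among the compounds with values here, with no direct precedent for 3-methylphenyl, compound 3 is expected to give a number close to that of compound 2, estimated at 10000 nM within 3000 nM to 30000 nM, a step of a 1.1-fold higher number from compound 2 to compound 3 (0.06 log units; within the scatter).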

Compound 3, half-maximal inhibitory concentration: 32100 nM
Compound 3: the middle estimate sits 3.2-fold (0.51 log units) below what was measured; the whole stated range lies below it.
By their numbers in this assay, from the lowest: compound 1; then compound 2; then compound 3.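

In this assay, for the compounds shown here, the group on this nitrogen has a larger effect than the single earlier step could show: 3-methylphenyl in place of 4-(trifluoromethoxy)phenyl gives a 3.7-fold higher number from compound 2 to compound 3 (0.56 log units; beyond the scatter). Set against 4-chloro-3-(trifluoromethyl)phenyl, the same group gives a 10-fold higher number from compound 1 to compound 3 (1.00 log units; beyond the scatter), so the three groups now span a wider range of numbers. Nothing available explains these steps.

From the compounds shown here alone, since both the substituent and its place on the ring change in these steps, their separate contributions remain open. A 4-methylphenyl or 3-(trifluoromethyl)phenyl group could help to separate them.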